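Swapping iodine for fluorine at a cytotoxicity limit

This account rests on a few compounds, and the source may have more. Where it says the series, first, only, none or still open, it means among the compounds named here.

Measured so far, each value a limit and not a number:
- Compound 1 `COc1cccc(C(=O)/C=C/c2ccc3c(c2)B(O)OC3)c1`: > 10 ug/mL
- Compound 2 `O=C(/C=C/c1ccc2c(c1)B(O)OC2)c1ccc(I)cc1`: > 10 ug/mL

Both results come from an ADME assay on L929 cells (Mus musculus) for cytotoxicity, read by resazurin assay, with a stated time of 72 h; on this read-out lower numbers stand for stronger inhibition and higher numbers for weaker inhibition. Only a limit is known for compound 2, which gives > 10 ug/mL in this assay. The one other result is also a limit, so what the two compounds share is the limit of > 10 ug/mL in this assay, at which 2 of the 2 values shown sit. Going by the values given here, neither gives an exact number, and no measured step links them.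

Compound 3 `O=C(/C=C/c1ccc2c(c1)B(O)OC2)c1cccc(F)c1` keeps the shared core and carries 3-fluorophenyl in place of 4-iodophenyl on a carbonyl carbon. Among the compounds with values here, with no measured step to lean on, the expectation starts from compound 2 at > 10 ug/mL, a limit that fixes no exact starting point. The estimated change a step that the limit leaves unreadable from compound 2 to compound 3 is expected to stay within the usual scatter of this assay, with no clear direction. Another result reported only as a limit is the likeliest outcome. If a number is obtained, the expected value for compound 3 is 12 ug/mL, with an estimated range of 5 ug/mL to 30 ug/mL.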

Compound 3, half-maximal inhibitory concentration: > 10 ug/mL
Compound 3: only a limit was reported (the forecaster's own chance of this, stated with the estimate: 70%); the middle value is on the limit's open side.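

The steps from compound 1 and from compound 2 to compound 3 cannot be read, because all three compounds give a limit and not a number: the limit of > 10 ug/mL in this assay, at which 3 of the 3 values shown sit.

The compounds shown leave open what exact value each would give in this assay, and whether the swapped groups make any difference to cytotoxicity.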